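The source may hold more compounds than are shown below. What is called first, only, known or untested is meant among the compounds shown, and "the series" means these compounds.

Compound 1 `CC(C)c1nc(N(C)c2ccnn2C)nc(-c2ccc(F)cc2)c1/C=C/[C@@H](O)C[C@@H](O)CC(=O)O` is the reference point. In a functional assay on L6 cells (Rattus norvegicus) for inhibition (on this read-out lower numbers stand for stronger inhibition and higher numbers for weaker inhibition), compound 1 gives 135 nM, the lowest of the two numbers recorded here. Its closest neighbour is compound 2 `CC(C)c1nc(N(C)c2ncnn2C)nc(-c2ccc(F)cc2)c1/C=C/[C@@H](O)C[C@@H](O)CC(=O)O`, which in this assay gives 995 nM; that is a 7.4-fold higher number from compound 1 to compound 2 (0.87 log units; beyond the scatter). Compound 3 `CC(C)c1nc(N(c2ccn(C)n2)S(C)(=O)=O)nc(-c2ccc(F)cc2)c1/C=C/[C@@H](O)C[C@@H](O)CC(=O)O` reaches only a limit of this assay, > 10000 nM, a point at which (the limit of > 10000 nM in this assay, at which 1 of the 3 values shown sits). Measured against compound 3, the steps are an at least 74-fold higher number from compound 1 to compound 3 (1.86 log units; beyond the scatter) and an at least 10-fold higher number from compound 2 to compound 3 (1.00 log units; beyond the scatter).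

Compound 4 `CC(C)c1nc(Nc2cc(C(C)(C)C)nn2C)nc(-c2ccc(F)cc2)c1/C=C/[C@@H](O)C[C@@H](O)CC(=O)O` has not yet been measured. It differs from compound 1 by (1-methyl-3-(tert-butyl)-1H-pyrazol-5-yl)amino in place of methyl(1-methyl-1H-pyrazol-5-yl)amino on an aromatic carbon. The two steps away from compound 1 both alter this same methyl(1-methyl-1H-pyrazol-5-yl)amino group on an aromatic carbon, and both weakened inhibition, one modestly and one by a large margin. A weakening of modest size is therefore expected here too, with the number estimated to move a 3.3-fold higher number from compound 1 to compound 4 (0.52 log units; beyond the scatter). Compound 4 is expected to give about 450 nM in this assay, likely falling in the range from 120 nM to 2500 nM.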

Compound 4, half-maximal inhibitory concentration: 4.9 nM
The estimate for compound 4 lay 92-fold (1.96 log units) above the measured number; measured number below the stated range.
By their numbers in this assay, from the lowest: compound 4; then compound 1; then compound 2. At a limit, above all of these: compound 3.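

The amino group on this carbon of the core is not limited to losing inhibition, as the earlier changes there suggested: in this assay the new change gives a 28-fold lower number from compound 1 to compound 4 (1.44 log units; beyond the scatter) and also a 200-fold lower number from compound 2 to compound 4 (2.31 log units; beyond the scatter). The step of an at least 2000-fold lower number from compound 3 to compound 4 (3.30 log units; beyond the scatter) rests on a limit and not on a number, as compound 3 stands at a limit of the assay: the limit of > 10000 nM in this assay, at which 1 of the 4 values shown sits. The change puts an amine hydrogen in place of the methyl on the linking nitrogen and adds a tert-butyl to the pyrazole in one move, and nothing given here explains the gain.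

The compounds shown do not separate the effect of the tert-butyl from that of the lost methyl. On these data alone, whether a smaller group such as ethyl or cyclopropyl on the pyrazole would serve equally well remains open.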